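This account rests on a few compounds, and the source may have more. Where it says the series, first, only, none or still open, it means among the compounds named here.

Going by the values given here, compound 1 `COc1cccc(-n2cc(COc3ccc4c(c3)CCC4)nn2)c1` is the one compound of this set with a measured result: in an ADME assay on HEK293 cells (Homo sapiens) for inhibition, read by MTT assay, with a stated time of 48 h, tested at 25 uM (on this read-out higher numbers stand for more inhibition at the one concentration tested (going by the name of the read-out) and lower numbers for less inhibition), compound 1 gives 25.8%. Compound 2 `Cc1ccc(-n2cc(COc3ccc4c(c3)CCC4)nn2)cc1` was run in this assay, but for compound 2 the entry reads "not determined" (no result reported), so there is nothing to place it on. Compound 3 `Fc1ccccc1-n1cc(COc2ccc3c(c2)CCC3)nn1` carries the shared core with the change (2-fluorophenyl in place of 4-methylphenyl on an aromatic nitrogen). Among the compounds with values here, with no value for compound 2, no step can be counted, and no shift beyond the usual scatter is expected in this assay. Compound 3 is estimated to give 25%, expected to fall between 5% and 50%.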

Compound 3, a percentage reported as inhibition, at one concentration (the size of the read-out at that concentration, not a potency): 21%
The estimate for compound 3 lay 4 percentage points above the measured number, and the stated range covers the measured number.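

In this assay, putting 2-fluorophenyl in place of 3-methoxyphenyl on the aromatic nitrogen gives a number 4.8 percentage points lower from compound 1 to compound 3 (within the scatter), so these two substituted phenyl groups cannot be told apart on this read-out; the step involving compound 2 cannot be read. Going by these compounds alone, this is the first comparison at this position, and it shows no change beyond the usual scatter. Nothing measured here offers a reason for this result.

Going by these compounds, it remains open whether a phenyl ring carrying an amine or a carboxylic acid would read differently. Replacing the ring with a longer chain is also untested among these compounds.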